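A side-chain exchange at the clearance limit

A few compounds are considered here, and "the series" means these few. Any claim that something is new, unique, unknown or untested is made for them only; others in the source may bear on it.

Measured in an ADME assay on microsomes from liver (Homo sapiens) for metabolic stability, read by LC-MS, tested at 1 uM; on this read-out lower numbers stand for slow clearance and higher numbers for fast clearance:
Compound 1 `NCCOCCOc1ccc([C@H]2CC[C@]3(CC2)OOC2(O3)C3CC4CC(C3)CC2C4)cc1`: < 7 mL.min-1.g-1, a limit
Compound 2 `c1cc([C@H]2CC[C@]3(CC2)OOC2(O3)C3CC4CC(C3)CC2C4)ccc1OCCC1CCNCC1`: < 7 mL.min-1.g-1, a limit

Compound 2 has no exact number, and its reading of < 7 mL.min-1.g-1 is a limit of the assay. Its standing is that of the whole small set, which sits at the limit of < 7 mL.min-1.g-1 in this assay, at which 2 of the 2 values shown sit. Compound 3 `N[C@H]1CC[C@@H](Oc2ccc([C@H]3CC[C@]4(CC3)OOC3(O4)C4CC5CC(C4)CC3C5)cc2)CC1` has not yet been measured, and it departs from compound 2 in a single place: 4-aminocyclohexyl in place of 2-(piperidin-4-yl)ethyl on an oxygen on an aromatic ring.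

Among the measured compounds shown here, only one measured step bears on this change, namely a step that the two limits leave unreadable from compound 1 to compound 2. That step concerns another exchange on the same chain, and it supplies no size that could be carried over. The two compounds nevertheless give the same kind of result, so no step beyond the scatter is expected in this assay, and no direction can be assigned. The change expected on this basis is a step that the limit leaves unreadable from compound 2 to compound 3. A reading reported only as a limit is the likeliest outcome. For compound 3 the estimated value is 5 mL.min-1.g-1, with an expected range from 2.5 mL.min-1.g-1 to 12 mL.min-1.g-1.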

Compound 3, intrinsic clearance in microsomes: < 7 mL.min-1.g-1
Compound 3 was reported as a limit; the forecaster's own chance of this, stated with the estimate: 70%; the middle value does not contradict the limit.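

In this assay, among the compounds shown here, compound 3 is reported as a limit, as are compound 1 and compound 2, so no step among the three compounds can be read: the limit of < 7 mL.min-1.g-1 in this assay, at which 3 of the 3 values shown sit.

Left open in this assay is the actual clearance of each compound, and so whether exchanging 2-(piperidin-4-yl)ethyl for 4-aminocyclohexyl changes clearance at all.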